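Para substituent swap on the phenyl of the shared core

The source may report more compounds than this note shows. Statements on the series, on what has been measured and on what is new or still open speak of the compounds shown alone.

The series shares the core of compound 1 `CC(C)c1ccc(-n2nc(-c3ccc(C(F)(F)F)cc3O)nc2-c2ccccc2O)cc1` and varies the group on the outer phenyl. In a functional assay on PC-12 cells (Rattus norvegicus) for cytotoxicity, read by MTT assay, with stated times of 2 h and 24 h, tested at 1 uM (a higher number here means a stronger effect of the compound at the concentration tested, a lower number a weaker effect), compound 1 gives 69.7%, the higher of the two numbers in hand. Compound 2 `Oc1cc(C(F)(F)F)ccc1-c1nc(-c2ccccc2O)n(-c2ccc(F)cc2)n1` carries fluoro in place of isopropyl on an aromatic carbon; in this assay compound 2 gives 67.2%, and the step of a number 2.5 percentage points lower from compound 1 to compound 2 (within the scatter) lies within the scatter. Compound 3 `Oc1cc(C(F)(F)F)ccc1-c1nc(-c2ccccc2O)n(-c2ccc(C(F)(F)F)cc2)n1` is the next member: trifluoromethyl in place of isopropyl on an aromatic carbon. Going by the values given here, the only measured step that bears on this change is the exchange of isopropyl for another small group at the same place, and it moved the read-out by only a number 2.5 percentage points lower from compound 1 to compound 2 (within the scatter). A step of no more than the scatter is therefore expected for compound 3, in either direction, a number 1.7 percentage points lower from compound 1 to compound 3 (within the scatter). For compound 3 the expected read-out in this assay is 68%, within a range of 57% to 79%.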

Compound 3, a percentage reported as activity, at one concentration (the size of the read-out at that concentration, not a potency): 70.7%
The estimate for compound 3 lay 2.7 percentage points below the measured number; the range from low to high includes it.
By their numbers in this assay, from the lowest: compounds 2, 1 and 3 (each within the scatter of the next).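

In this assay, trifluoromethyl on this aromatic carbon, para to a large group, gives a number 1 percentage points higher from compound 1 to compound 3 (within the scatter), and the exchange of fluoro for trifluoromethyl at the same place gives a number 3.5 percentage points higher from compound 2 to compound 3 (within the scatter). Isopropyl, fluoro and trifluoromethyl can now be compared pairwise at this one place, and all three steps lie within the scatter, so this read-out does not separate compounds 1, 2 and 3. The second step adds a comparison that does not involve isopropyl, so the absence of separation does not rest on steps from compound 1 alone. No measurement at hand offers an explanation for this result.

On these data alone, whether an amine, a carboxylic acid or a longer alkyl chain at this place would move the read-out beyond the scatter stays open. Also open, as far as these compounds go, is whether compounds 1, 2 and 3 would still read alike at a concentration other than the single one tested.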